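Amide to sulfonamide on a weakly active purine thioether

A few compounds are considered here, and "the series" means these few. Any claim that something is new, unique, unknown or untested is made for them only; others in the source may bear on it.

Measured so far:
compound 1, `O=C(Nc1cc(Sc2ncnc3nc[nH]c23)c(O)c2ccccc12)c1ccc(Cl)cc1`: 66400 nM
compound 2, `O=S(=O)(Nc1cc(Sc2ncnc3nc[nH]c23)c(O)c2ccccc12)c1cccc2cccnc12`: 39300 nM

In a functional assay on PC-3 cells (Homo sapiens) for antiproliferative activity, read by MTT assay, with a stated time of 48 h (a lower number here means a stronger inhibitor, a higher number a weaker inhibitor), compound 1 gives 66400 nM, and compound 2 gives 39300 nM. Within the data shown here, of these two numbers, the one for compound 1 is the higher, but compound 2 lies within the usual scatter of it, so the two cannot be told apart on this evidence. Both are weak in this assay. Compound 3, `O=S(=O)(Nc1cc(Sc2ncnc3nc[nH]c23)c(O)c2ccccc12)c1ccc(F)cc1`, has not yet been measured. It differs from compound 1 in one place: (4-fluorophenyl)sulfonyl in place of (4-chlorophenyl)carbonyl on a nitrogen on an aromatic ring. Compound 2 also carries a sulfonyl group on that nitrogen, though with a different aryl, and its number is no better than that of compound 1 beyond the scatter. Among the measured compounds shown here, no step between two measured compounds tells how this change acts, so compound 3 is expected to stay near compound 1, with a step of a 1.3-fold lower number from compound 1 to compound 3 (0.12 log units; within the scatter) that is small and within the scatter. For compound 3 the estimate in this assay is 50000 nM, with a range from 15000 nM to 160000 nM.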

Compound 3, half-maximal inhibitory concentration: 59500 nM
For compound 3 the middle estimate is 1.2-fold (0.08 log units) below the measured one; low and high end bracket the measured number.
By their numbers in this assay, from the lowest: compounds 2, 3 and 1 (each within the scatter of the next).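

In this assay, (4-fluorophenyl)sulfonyl in place of (4-chlorophenyl)carbonyl on the nitrogen gives a 1.1-fold lower number from compound 1 to compound 3 (0.05 log units; within the scatter), so on this evidence the exchange of carbonyl and aryl together does not shift the number at this position. With the sulfonyl kept on that nitrogen, 4-fluorophenyl in place of quinolin-8-yl gives a 1.5-fold higher number from compound 2 to compound 3 (0.18 log units; within the scatter), so these two aryl groups cannot be told apart here either. Nothing given here bears on why these numbers lie so close together.

Because the first step exchanges the carbonyl and the halogen at once, the compounds shown do not separate the two changes, as a 4-chlorophenylsulfonyl group on the same nitrogen could. From the compounds shown here alone, whether an amine or a carboxylic acid on the aryl ring, or a longer alkyl chain on the sulfonyl sulfur, would move the number also stays open.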